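Replacing the bromophenyl arm with an acetamide chain

The source may hold more compounds than are shown below. What is called first, only, known or untested is meant among the compounds shown, and "the series" means these compounds.

In a functional assay on HCT-116 cells (Homo sapiens) for inhibition, read by MTT assay, with a stated time of 72 h (a higher number here means a weaker inhibitor, a lower number a stronger inhibitor), compound 2 `COc1cc(Oc2cccc(Nc3ccccc3)c2)cc(OC)c1CNCc1ccc(Br)cc1` gives 6230 nM. Compound 3 `COc1cc(Oc2cccc(Nc3ccccc3)c2)cc(OC)c1CNCc1ccc(Cl)cc1` gives 3310 nM and compound 1 `COc1ccc(CCCNCc2c(OC)cc(Oc3ccc(Nc4ccccc4)cc3)cc2OC)cc1` gives 3230 nM; all three numbers lie within the scatter of one another, so none of them can be set apart from the others. Going by the values given here, the one measured single-point step, a 1.9-fold lower number from compound 2 to compound 3 (0.27 log units; within the scatter), is itself within the scatter. Compound 4 `COc1cc(Oc2cccc(Nc3ccccc3)c2)cc(OC)c1CNCCNC(C)=O` differs from compound 2 by acetamidomethyl in place of 4-bromophenyl on a saturated chain carbon bound to an amine nitrogen. The measured step exchanges one halogen for another and says nothing about trading the ring for a chain carrying a donor and an acceptor, so the expectation rests on compound 2 alone. The expected step is a 1.0-fold lower number from compound 2 to compound 4 (0.02 log units; within the scatter), no clear direction beyond the scatter. Compound 4 is estimated at 6000 nM, ranging from 1800 nM to 20000 nM.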

Compound 4, half-maximal inhibitory concentration: 18200 nM
Compound 4: the middle estimate sits 3.0-fold (0.48 log units) below what was measured, within the range that was stated.
By their numbers in this assay, from the lowest: compounds 1, 3 and 2 (each within the scatter of the next); then compound 4.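

In this assay, going by these compounds alone, this position gives the first change beyond the scatter: acetamidomethyl in place of the halophenyl ring weakens inhibition, with a 2.9-fold higher number from compound 2 to compound 4 (0.47 log units; beyond the scatter) and a 5.5-fold higher number from compound 3 to compound 4 (0.74 log units; beyond the scatter). The halogen swap had separated nothing, so this shows that the arm on the saturated chain carbon is not indifferent to exchanging the aromatic ring for an acetamide chain. No evidence on the cause of this weakening is available.

Going by these compounds, whether the ring's departure or the amide's arrival drives the step remains open. A plain butyl chain, or a phenyl ring bearing an acetamide, would separate the two.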